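The compounds below may be only part of what the source reports. "The series", "measured", "known", "first", "only" and "open" are said of these compounds alone.

Working notes on the series. In a functional assay on RS4-11 cells (Homo sapiens) for inhibition, read by CCK-8 assay, with a stated time of 48 h, tested at 20 uM (on this read-out lower numbers stand for less inhibition of growth and higher numbers for more inhibition of growth at the one concentration tested), compound 1 (`COc1ccc(S(=O)(=O)Oc2ccccc2/C=C(\C#N)C(=O)Nc2nnc(Cc3cccc4ccccc34)s2)cc1`) gives 78%, compound 2 (`N#C/C(=C\c1ccccc1OS(=O)(=O)c1ccccc1[N+](=O)[O-])C(=O)Nc1nnc(Cc2cccc3ccccc23)s1`) gives 66% and compound 3 (`N#C/C(=C\c1ccccc1OS(=O)(=O)c1ccc(Cl)cc1)C(=O)Nc1nnc(Cc2cccc3ccccc23)s1`) gives 68%. Compound 1 therefore stands above compound 2 by more than the scatter, but it cannot be separated from compound 3.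

The next compound is compound 4 (`COc1ccc(S(=O)(=O)Oc2ccccc2/C=C(\C#N)C(=O)Nc2nnc(Cc3ccc(C)cc3)s2)cc1`), which has 4-methylphenyl in place of naphthalen-1-yl on a saturated chain carbon bound to an aromatic carbon. The aryl group on the sulfonyl sulfur stays as in compound 1.

Among the measured compounds shown here, no measured step touches this place, since all three measured compounds carry naphthalen-1-yl. The available steps all concern the aryl group on the sulfonyl sulfur: a number 12 percentage points lower from compound 1 to compound 2 (beyond the scatter), a number 10 percentage points lower from compound 1 to compound 3 (within the scatter) and a number 2 percentage points higher from compound 2 to compound 3 (within the scatter). For the measured compounds named here, they show only that changes elsewhere on the shared core have so far moved this assay modestly or not beyond the scatter. They give no direction for the new change, so any direction is tentative.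

A modest fall is expected, mainly since compound 1 starts from 78%, the top of the measured numbers, but a step within the scatter remains possible. The expected size is a number 14 percentage points lower from compound 1 to compound 4 (beyond the scatter). For compound 4 the estimated value is 64%, with an expected range of 42% to 82%.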

Compound 4, percent growth inhibition at one concentration: 79%
Estimate against measurement, compound 4: 15 percentage points below, and the stated range covers the measured number.
By their numbers in this assay, from the lowest: compounds 2, 3, 1 and 4 (each within the scatter of the next, the first and the last beyond it).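

Among the compounds shown here, this is the first reading at the saturated chain carbon bound to an aromatic carbon: in this assay, 4-methylphenyl in place of naphthalen-1-yl gives a number 1 percentage points higher from compound 1 to compound 4 (within the scatter). The group that leaves has 10 heavy atoms and 2 six-membered aromatic rings of carbon only, and the group that enters has 7 heavy atoms and one such ring, so on this one pair, with the 4-methoxyphenyl group on the sulfonyl sulfur held fixed, the smaller group keeps the growth inhibition at the one concentration tested. No measurement in hand bears on why the two compounds read alike.

The compounds shown leave open whether the same exchange would read alike with the 2-nitrophenyl or 4-chlorophenyl group on the sulfonyl sulfur, since the 4-methylphenyl group appears here only with 4-methoxyphenyl. They also leave open how far this position tolerates other groups, such as an unsubstituted phenyl, a phenyl bearing a carboxylic acid or an amine, or a longer chain between the aromatic ring and the shared core.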